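The source may report more compounds than this note shows. Statements on the series, on what has been measured and on what is new or still open speak of the compounds shown alone.

Measured so far in an ADME assay on HUVEC cells (Homo sapiens) for cytotoxicity, read by MTT assay, with a stated time of 48 h; on this read-out higher numbers stand for weaker inhibition and lower numbers for stronger inhibition:
compound 1 `Cc1ccc(-c2cn(/N=C/c3cc4ccccc4nc3Cl)c(N)n2)cc1` gives > 50000 nM, which is a limit of this assay rather than a number.
compound 2 `Cc1ccc2nc(Cl)c(/C=N/n3cc(-c4ccccc4)nc3N)cc2c1` gives 41500 nM.
compound 3 `Cc1ccc(-c2cn(/N=C/c3cc4cc(C)ccc4nc3Cl)c(N)n2)cc1` gives 18000 nM.

Compound 3 holds the lowest of the two real numbers, with compound 2 nearest. Both measured steps add a methyl in place of hydrogen on an aromatic carbon: a 2.3-fold lower number from compound 2 to compound 3 (0.36 log units; beyond the scatter) on the phenyl ring, and an at least 2.7-fold lower number from compound 1 to compound 3 (0.44 log units; beyond the scatter) on the other ring. The latter can only be bounded, because compound 1 sits at the limit of > 50000 nM in this assay, at which 1 of the 3 values shown sits.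

Compound 4 `Cc1ccc2nc(Cl)c(/C=N/n3cc(-c4ccc(Cl)cc4)nc3N)cc2c1` differs from compound 3 by chloro in place of methyl on an aromatic carbon. Going by the values given here, no measured step swaps methyl for chloro; the step from compound 2 to compound 3 is the only one touching this position, and it was modest. The expected step of no change at the digits printed from compound 3 to compound 4 (within the scatter) is therefore none beyond the scatter. Compound 4 is estimated at 18000 nM, between 8000 nM and 40000 nM.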

Compound 4, half-maximal inhibitory concentration: 38500 nM
Compound 4: the middle estimate sits 2.1-fold (0.33 log units) below what was measured; the range from low to high includes it.
By their numbers in this assay, from the lowest: compound 3; then compounds 4 and 2 (each within the scatter of the next). At a limit, above all of these: compound 1.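

In this assay, the change from 4-methylphenyl to 4-chlorophenyl gives a 2.1-fold higher number from compound 3 to compound 4 (0.33 log units; beyond the scatter) and so undoes the gain seen with methyl. Chloro in place of hydrogen gives a 1.1-fold lower number from compound 2 to compound 4 (0.03 log units; within the scatter), so of the three groups shown at this position, only methyl stands apart. Nothing shown here explains why methyl and chloro differ. Going by these compounds, whether an amine, a methoxy group or a longer chain at this position would behave like methyl or like chloro remains open.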